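A few compounds are considered here, and "the series" means these few. Any claim that something is new, unique, unknown or untested is made for them only; others in the source may bear on it.

Measured so far in an ADME assay on HEp-2 cells (Homo sapiens) for cytotoxicity, read by MTT assay, with a stated time of 3 days; a lower number here means that less compound is tolerated, a higher number that more compound is tolerated:
compound 1, `CC[C@H](CCn1cncn1)c1ccc(F)cc1` — 103 ug/mL
compound 2, `CC[C@@H](CCn1cncn1)c1ccc(F)cc1` — 90.3 ug/mL

On the two numbers shown, compound 2 sits at one end with compound 1 nearest; the step of a 1.1-fold lower number from compound 1 to compound 2 (0.06 log units; within the scatter) lies within the scatter, so the two compounds are not told apart in this assay. That step rests on the fact that compounds 1 and 2 differ only in the configuration as drawn and concerns configuration alone.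

Compound 3, `CC[C@@H](CCn1cncn1)c1ccc(OC)cc1`, differs from compound 2 by methoxy in place of fluoro on an aromatic carbon. For the measured compounds named here, no measured step here covers a change of this kind: the one step on record, a 1.1-fold lower number from compound 1 to compound 2 (0.06 log units; within the scatter), does not touch the substituent on the aromatic ring. For compound 3 in this assay the expectation therefore stays close to compound 2, with a step of a 1.0-fold lower number from compound 2 to compound 3 (0.00 log units; within the scatter) expected to remain within the scatter. The estimate for compound 3 in this assay is 90 ug/mL, expected to fall between 45 ug/mL and 180 ug/mL.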

Compound 3, half-maximal cytotoxic concentration: 146 ug/mL
Compound 3: the middle estimate sits 1.6-fold (0.21 log units) below what was measured; the range from low to high includes it.
By their numbers in this assay, from the lowest: compounds 2, 1 and 3 (each within the scatter of the next).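

In this assay, for the compounds shown here, the one change on the aromatic ring, methoxy in place of fluoro para to a large group, gives a 1.6-fold higher number from compound 2 to compound 3 (0.21 log units; within the scatter) and so does not tell the two compounds apart. At this position, the exchange of a lone fluorine for methoxy, with its oxygen and hydrogen-bond acceptor, therefore stays within the scatter, whereas the earlier pair spoke only to configuration. No available fact bears on this substituent change.

Open, on these data alone, is whether an amine, a carboxylic acid or a longer alkoxy chain at this place would also stay within the scatter. Also open is whether methoxy reads the same on the configuration drawn in compound 1, since the ring change is shown on one configuration only.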